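A few compounds are considered here, and "the series" means these few. Any claim that something is new, unique, unknown or untested is made for them only; others in the source may bear on it.

Measured so far in an ADME assay on MT2 cells (Homo sapiens) for cytotoxicity, read by XTT assay, with a stated time of 4 days; a lower number here means that less compound is tolerated, a higher number that more compound is tolerated:
compound 1 `Cc1cc(/C=C2\SC(=S)N(Cc3ccc(Br)cc3)C2=O)c(C)n1-c1ccc(O)c(C(=O)O)c1`: 94400 nM
compound 2 `Cc1cc(/C=C2\SC(=S)N(Cc3cccc(C(F)(F)F)c3)C2=O)c(C)n1-c1ccc(O)c(C(=O)O)c1`: 26300 nM

Compound 2 holds the lower of the two numbers in this assay, so on the two values shown it is the compound of which less is tolerated by the cells. Going by the values given here, the only step on record is a 3.6-fold lower number from compound 1 to compound 2 (0.56 log units; beyond the scatter), which came with 3-(trifluoromethyl)phenyl in place of 4-bromophenyl on a saturated chain carbon bound to an amide-type nitrogen in a ring.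

Compound 3 `Cc1cc(/C=C2\SC(=S)N(Cc3ccccc3C(F)(F)F)C2=O)c(C)n1-c1ccc(O)c(C(=O)O)c1` is not yet measured. It differs from compound 2 only in the arrangement of the same atoms: 2-(trifluoromethyl)phenyl in place of 3-(trifluoromethyl)phenyl on a saturated chain carbon bound to an amide-type nitrogen in a ring. Among the compounds with values here, no measured step covers this kind of change; the one step known exchanges one group for another and is not a shift of the trifluoromethyl around the ring. The shared core, the substituted phenol with its carboxylic acid and the rhodanine-type ring, is untouched. With nothing in the data to point either way, the step of a 1.0-fold lower number from compound 2 to compound 3 (0.00 log units; within the scatter) is expected to stay within the scatter. Compound 3 is therefore estimated at 26000 nM, with a range from 9000 nM to 75000 nM.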

Compound 3, half-maximal cytotoxic concentration: 28800 nM
For compound 3 the middle estimate is 1.1-fold (0.04 log units) below the measured one; measured number inside the range.
By their numbers in this assay, from the lowest: compounds 2 and 3 (each within the scatter of the next); then compound 1.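

In this assay the shift to 2-(trifluoromethyl)phenyl from 3-(trifluoromethyl)phenyl, on a saturated chain carbon bound to an amide-type nitrogen in a ring, gives a 1.1-fold higher number from compound 2 to compound 3 (0.04 log units; within the scatter) and so does not separate the two arrangements at this position. The exchange of 4-bromophenyl now has a second reading, a 3.3-fold lower number from compound 1 to compound 3 (0.52 log units; beyond the scatter) alongside a 3.6-fold lower number from compound 1 to compound 2 (0.56 log units; beyond the scatter) as the earlier one, and with both beyond the scatter, compound 1 stands apart from either trifluoromethyl arrangement. No measured information on the origin of these numbers accompanies the series.

The compounds shown leave open where 4-(trifluoromethyl)phenyl would fall, so the change of group from bromine to trifluoromethyl cannot yet be told apart from the change in where the group sits on the phenyl. Also open, from the compounds shown here alone, is how a phenyl carrying an amine or a carboxylic acid, or a longer chain in place of the single saturated carbon, would read at this place in the same assay.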